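The source may hold more compounds than are shown below. What is called first, only, known or untested is meant among the compounds shown, and "the series" means these compounds.

Working notes on the series.

Compound 2 `Nc1ccccc1NC(=O)c1ccc(CSC(=S)N2CCN(c3ccncc3)CC2)cc1` gives 77.4% in a functional assay on HeLa cells (Homo sapiens) for antiproliferative activity, read by CCK-8 assay, with a stated time of 72 h, tested at 8 uM (a lower number here means a weaker effect, a higher number a stronger effect of the compound at the concentration tested), and has the highest number of the three measured here. Compound 1 `CN(Cc1ccncc1)C(=S)SCc1ccc(C(=O)Nc2ccccc2N)cc1` gives 72.7% in this assay, a number within the scatter of compound 2, so no order between these two can be read from the data. Compound 3 `Nc1ccccc1NC(=O)c1ccc(CSC(=S)N(Cc2ccccc2)Cc2ccccc2)cc1` gives 18.9% in this assay, which lies well beyond the scatter under compound 2 and compound 1.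

Compound 4 `Nc1ccccc1NC(=O)c1ccc(CSC(=S)N2CCN(Cc3cccnc3)CC2)cc1` is the next compound for this assay. Relative to compound 2 it differs in one place: (pyridin-3-yl)methyl in place of pyridin-4-yl on an amine nitrogen in a ring. Among the measured compounds shown here, no step between two measured compounds that differ in one place is available, so the size of the change in this assay is not anchored. Two compounds with a pyridine-bearing amine, compound 2 and compound 1, both sit high, and compound 1 holds its number with an acyclic amine carrying a different arrangement, while only compound 3 with two benzyl groups drops. A step of modest size, most likely downward but possibly none beyond the scatter, is expected for a number 11.4 percentage points lower from compound 2 to compound 4 (beyond the scatter). For compound 4 the expected value is 66%, with a range from 42% to 84%.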

Compound 4, a percentage reported as inhibition, at one concentration (the size of the read-out at that concentration, not a potency): 78%
Estimate against measurement, compound 4: 12 percentage points below, within the range that was stated.
By their numbers in this assay, from the lowest: compound 3; then compounds 1, 2 and 4 (each within the scatter of the next).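

In this assay, among the compounds shown here, the replacement of pyridin-4-yl by (pyridin-3-yl)methyl on the amine nitrogen in the ring gives a number 0.6 percentage points higher from compound 2 to compound 4 (within the scatter) as the first step between two measured compounds that differ in one place. This position therefore accepts a change of this kind, in which the group gains a heavy atom and the pyridine is attached differently, with no change in this read-out that can be told from the usual scatter, although a read-out at one concentration is not a potency and a difference in potency could remain unseen. No available evidence bears on why the number holds at this position.

The change alters the attachment of the pyridine and the place of its ring nitrogen together, so the compounds shown cannot assign any share of the outcome to either alteration. A pyridin-2-yl or a plain phenyl on the same amine nitrogen would test whether the pyridine nitrogen matters here at all, and a full concentration series for compound 2 and compound 4 would show whether the two also match in potency.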